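Acetamido for nitro on a weak sulfonyl compound

The source may report more compounds than this note shows. Statements on the series, on what has been measured and on what is new or still open speak of the compounds shown alone.

In a functional assay on SMMC-7721 cells (Homo sapiens) for cytotoxicity, read by MTT assay, with a stated time of 24 h (a lower number here means a stronger inhibitor, a higher number a weaker inhibitor), compound 1 `CN1C/C(=C\c2ccncc2)C(=O)/C(=C/c2ccccc2C(F)(F)F)C1` gives 4100 nM and compound 2 `O=C1/C(=C/c2ccncc2)CNC/C1=C\c1ccccc1C(F)(F)F` gives 4500 nM (a 1.1-fold higher number from compound 1 to compound 2 (0.04 log units; within the scatter)). Compound 3 `O=C1/C(=C/c2ccncc2)CN(S(=O)(=O)c2ccc([N+](=O)[O-])cc2)C/C1=C\c1ccccc1C(F)(F)F` gives > 20000 nM as a limit of the assay, not a number. Placing its (4-nitrophenyl)sulfonyl group on the amine nitrogen gave two measured steps (an at least 4.8-fold higher number from compound 1 to compound 3 (0.68 log units; beyond the scatter); an at least 4.4-fold higher number from compound 2 to compound 3 (0.64 log units; beyond the scatter)). Compound 4 `CC(=O)Nc1ccc(S(=O)(=O)N2C/C(=C\c3ccncc3)C(=O)/C(=C/c3ccccc3C(F)(F)F)C2)cc1` carries acetamido in place of nitro on an aromatic carbon, para to a large group (acetamido in place of nitro on an aromatic carbon). Among the compounds with values here, no measured step changes that position. Compound 4 keeps the sulfonyl link, so the loss seen in an at least 4.4-fold higher number from compound 2 to compound 3 (0.64 log units; beyond the scatter) is expected to largely persist. Only a small move toward a lower number is expected (an at least 1.6-fold lower number from compound 3 to compound 4 (0.22 log units; that floor lies within the scatter)). For compound 4 the estimate is 12000 nM, within a range of 4000 nM to 25000 nM.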

Compound 4, half-maximal inhibitory concentration: 5760 nM
For compound 4 the middle estimate is 2.1-fold (0.32 log units) above the measured one; low and high end bracket the measured number.
By their numbers in this assay, from the lowest: compounds 1, 2 and 4 (each within the scatter of the next). At a limit, above all of these: compound 3.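

In this assay, compound 4 keeps the sulfonyl link, yet 4-acetamidophenyl in place of 4-nitrophenyl gives an at least 3.4-fold lower number from compound 3 to compound 4 (0.54 log units; beyond the scatter). The sulfonyl link alone therefore does not account for the weak result of compound 3, and the group on this aromatic carbon, para to a large group, also matters. Compound 3 stands at a limit, so the true size of this step stays unknown: the limit of > 20000 nM in this assay, at which 1 of the 4 values shown sits.

The compounds shown leave open how an amine or a carboxylic acid on this carbon would read, and whether a longer chain in place of acetamido would keep the gain.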